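A few compounds are considered here, and "the series" means these few. Any claim that something is new, unique, unknown or untested is made for them only; others in the source may bear on it.

Measured so far in a functional assay on Huh-7 cells (Homo sapiens) for inhibition, read by CCK-8 assay, with a stated time of 72 h; a lower number here means a stronger inhibitor, a higher number a weaker inhibitor:
- compound 1 `O=C(/C=C/c1cccnc1)NCCCc1ccc(S(=O)(=O)Nc2ccccc2)cc1`: > 10000 nM, a limit of the assay and not a number
- compound 2 `O=C(/C=C/c1cccnc1)NCCCCCCCc1ccc(S(=O)(=O)Nc2ccccc2)cc1`: 1230 nM
- compound 3 `Cc1ccc(NS(=O)(=O)c2cccc(CCCCCCNC(=O)/C=C/c3cccnc3)c2)cc1`: 6.92 nM

Compound 3 at 6.92 nM holds the lowest number shown. Compound 2 stands at 1230 nM, and the gap between the two lies beyond the scatter.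

Compound 4 `O=C(/C=C/c1cccnc1)NCCCCCCc1cccc(S(=O)(=O)Nc2ccc(Cl)cc2)c1` is the next entry, with chloro in place of methyl on an aromatic carbon, para to a large group: chloro in place of methyl on an aromatic carbon. Among the measured compounds shown here, no measured pair isolates this kind of change, so the expectation rests on compound 3 at 6.92 nM. The expected step of a 1.2-fold higher number from compound 3 to compound 4 (0.06 log units; within the scatter) in this assay is small, with no direction beyond the scatter. For compound 4 the estimate is 8 nM, with an expected range of 2 nM to 30 nM.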

Compound 4, half-maximal inhibitory concentration: 24.1 nM
For compound 4 the middle estimate is 3.0-fold (0.48 log units) below the measured one; low and high end bracket the measured number.
By their numbers in this assay, from the lowest: compound 3; then compound 4; then compound 2. At a limit, above all of these: compound 1.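

Among the compounds shown here, the 4-methylphenyl to 4-chlorophenyl exchange is the first single-place change readable, and in this assay it gives a 3.5-fold higher number from compound 3 to compound 4 (0.54 log units; beyond the scatter). This position, para to a large group, therefore responds to chloro in place of methyl, though only modestly, with compound 4 still at 24.1 nM. Nothing on hand bears on the cause of this step.

Open, going by these compounds, is how an amine, a methoxy group or a carboxylic acid at this position would compare. Also open, on these data alone, is whether the same step holds with a longer chain.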